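This account rests on a few compounds, and the source may have more. Where it says the series, first, only, none or still open, it means among the compounds named here.

Among the compounds with values here, in a functional assay on MCF7 cells (Homo sapiens) for antiproliferative activity, read by MTT assay (a lower number here means a stronger inhibitor, a higher number a weaker inhibitor), compound 1 `COc1ccccc1NC(=O)Nc1ccc(Oc2ccnc3cc(OCCCCCCC(=O)NO)c(OC)cc23)cc1` gives 6280 nM and compound 2 `COc1cc2c(Oc3ccc(NC(=O)N/N=C/c4ccccc4)cc3)ccnc2cc1OCCCCCCC(=O)NO` gives 610 nM as the lower of the two numbers measured so far. Compound 3 `COc1cc2c(Oc3ccc(NC(=O)NNC(=O)c4cccc(C)c4)cc3)ccnc2cc1OCCCCCCC(=O)NO` keeps the shared core of compound 2 and differs in one place: a group of 10 heavy atoms (8 carbon, 1 nitrogen, 1 oxygen; one six-membered aromatic ring of carbon only) in place of a group of 8 heavy atoms (7 carbon, 1 nitrogen; one six-membered aromatic ring of carbon only), on an amide-type nitrogen. The entering ((3-methylphenyl)carbonyl)amino group, like the group it replaces, holds one six-membered aromatic ring of carbon only and sits on an amide-type nitrogen. Within the data shown here, one measured step bears on this place: a 10-fold lower number from compound 1 to compound 2 (1.01 log units; beyond the scatter), a large change beyond the scatter, also made on an amide-type nitrogen. That single step shows that the number can move far with the group at this nitrogen, but it gives no direction for the new group. Among the measured compounds shown here, the data hold no measured compound with this group, so the expectation stays close to compound 2 with a wide margin. The expected change is a 1.6-fold higher number from compound 2 to compound 3 (0.21 log units; within the scatter) in this assay, a small move toward a higher number. For compound 3 the estimated value is 1000 nM, with an expected range from 250 nM to 4000 nM in this test.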

Compound 3, half-maximal inhibitory concentration: 5830 nM
Beside the measured number, compound 3's estimate is 5.8-fold (0.77 log units) below it, and the stated range ends below it.
By their numbers in this assay, from the lowest: compound 2; then compounds 3 and 1 (each within the scatter of the next).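

In this assay, within the data shown here, ((3-methylphenyl)carbonyl)amino on the amide-type nitrogen gives a 9.6-fold higher number from compound 2 to compound 3 (0.98 log units; beyond the scatter), the first step at this place that runs toward a higher number, whereas the only earlier step ran the other way, with a 10-fold lower number from compound 1 to compound 2 (1.01 log units; beyond the scatter). Set against 2-methoxyphenyl at the same nitrogen, the entering group gives a 1.1-fold lower number from compound 1 to compound 3 (0.03 log units; within the scatter), so these two groups are not told apart in this assay, and among the three compounds only compound 2 stands apart from the others, with steps beyond the scatter to both. Nothing in the material at hand accounts for this result, so the change is recorded here only as a measured difference.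

The compounds shown leave open which part of the change carries the step, since the entering group differs from the group it replaces both in its carbonyl and in its methyl on the aromatic ring. A benzoylamino group without the methyl, or a benzylamino group at the same nitrogen, would separate these parts and show whether the lower number of compound 2 goes with its own link to the ring.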